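Replacing the Triazole Aryl Group with a Hydroxypropyl Chain

This account rests on a few compounds, and the source may have more. Where it says the series, first, only, none or still open, it means among the compounds named here.

Measured compounds:
compound 1, `CN(CCNCc1cn(-c2ccccc2)nn1)CCNc1ccnc2cc(Cl)ccc12`: 25000 nM
compound 2, `CN(CCNCc1cn(-c2ccccc2Cl)nn1)CCNc1ccnc2cc(Cl)ccc12`: 20000 nM
compound 3, `CN(CCNCc1cn(Cc2ccccc2)nn1)CCNc1ccnc2cc(Cl)ccc12`: 32000 nM

In a functional assay on NCI-H460 cells (Homo sapiens) for antiproliferative activity, read by sulforhodamine B assay, with a stated time of 72 h (on this read-out lower numbers stand for stronger inhibition and higher numbers for weaker inhibition), compound 3 gives the highest of the three numbers, yet every comparison among them falls within the scatter: a 1.3-fold higher number from compound 1 to compound 3 (0.11 log units; within the scatter) and a 1.6-fold higher number from compound 2 to compound 3 (0.20 log units; within the scatter). The same holds for a 1.3-fold lower number from compound 1 to compound 2 (0.10 log units; within the scatter). Across these three compounds, the changes made to the group on the aromatic nitrogen have not moved the read-out beyond the scatter, so compound 3 stands in a narrow band with the other two rather than apart from them.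

Compound 4, `CN(CCNCc1cn(CCCO)nn1)CCNc1ccnc2cc(Cl)ccc12`, differs from compound 3 in one place: 2-hydroxyethyl in place of phenyl on a saturated chain carbon bound to an aromatic nitrogen. Among the compounds with values here, none of the measured steps involves a chain of this kind at this position; the steps among phenyl, 2-chlorophenyl and benzyl bear on it only by showing that this position has so far tolerated change without any step beyond the scatter. The present change is larger than those, so the direction is open, but nothing in the data points to a departure from the band around compound 3, and a step of a 1.1-fold higher number from compound 3 to compound 4 (0.04 log units; within the scatter) is expected, which would lie within the scatter. Compound 4 is therefore estimated at 35000 nM in this assay, with a range from 15000 nM to 80000 nM.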

Compound 4, half-maximal inhibitory concentration: > 200000 nM
Compound 4: a limit, no number; the forecaster's own chance of this, stated with the estimate: 20%; middle value at least 5.7-fold (0.75 log units) away from the limit.
By their numbers in this assay, from the lowest: compounds 2, 1 and 3 (each within the scatter of the next). At a limit, above all of these: compound 4.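

In this assay compound 4 gives a limit of the assay and not a number: the limit of > 200000 nM in this assay, at which 1 of the 4 values shown sits. Even read from that limit, the change at this position gives an at least 6.2-fold higher number from compound 3 to compound 4 (0.79 log units; beyond the scatter), and the comparisons with the two compounds carrying an aryl group on the aromatic nitrogen give an at least 8.0-fold higher number from compound 1 to compound 4 (0.90 log units; beyond the scatter) and an at least 10-fold higher number from compound 2 to compound 4 (1.00 log units; beyond the scatter). The group on the aromatic nitrogen is therefore not free to vary without consequence, as the steps among phenyl, 2-chlorophenyl and benzyl, all within the scatter, had suggested: moving from these ring-bearing groups to the 3-hydroxypropyl chain takes the read-out out of their narrow band, by an amount that has only a lower bound.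

The compounds shown do not separate the departure of the ring from the arrival of the hydroxy group, so it stays open whether a plain propyl chain would sit with compound 3 or with compound 4. They also leave open whether an amine or a carboxylic acid at the end of the chain, or a longer chain carrying the same hydroxy group, would return the read-out to that band.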